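Adding a Methoxy Group to Compound 1

A few compounds are considered here, and "the series" means these few. Any claim that something is new, unique, unknown or untested is made for them only; others in the source may bear on it.

Measured so far in a functional assay on CNE-2 cells (Homo sapiens) for cytotoxicity, read by sulforhodamine B assay, with a stated time of 48 h; a higher number here means a weaker inhibitor, a lower number a stronger inhibitor:
Compound 1 `COc1ccc(/C=C/C(=O)c2ccc(N)c(-c3ccc(F)cc3)c2)cc1OC` gives 3510 nM
Compound 2 `COc1ccc(/C=C/C(=O)c2cccc(-c3ccc(F)cc3)c2)cc1OC` gives 5550 nM
Compound 3 `COc1ccc(/C=C/C(=O)c2ccc(NC(C)=O)c(-c3ccc(F)cc3)c2)cc1OC` gives 2740 nM

Among these three numbers compound 1 stands second highest. Its nearest neighbour is compound 3, reached by a 1.3-fold lower number from compound 1 to compound 3 (0.11 log units; within the scatter); its furthest is compound 2, reached by a 1.6-fold higher number from compound 1 to compound 2 (0.20 log units; within the scatter). Within the data shown here, the only step beyond the scatter is a 2.0-fold lower number from compound 2 to compound 3 (0.31 log units; beyond the scatter), a modest one. All three steps concern the amino group and its acetyl on the ring carrying the fluorophenyl group.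

Compound 4 `COc1cc(/C=C/C(=O)c2ccc(N)c(-c3ccc(F)cc3)c2)cc(OC)c1OC` differs from compound 1 as follows: methoxy in place of hydrogen on an aromatic carbon. Among the measured compounds shown here, this change sits on the other ring, which no measured step touches, so none of the three steps bears on it. Nothing here points in either direction, and the step of a 1.0-fold lower number from compound 1 to compound 4 (0.00 log units; within the scatter) is therefore expected to stay within the scatter. Compound 4 is estimated to give 3500 nM, with a range from 1500 nM to 8000 nM.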

Compound 4, half-maximal inhibitory concentration: 4600 nM
Beside the measured number, compound 4's estimate is 1.3-fold (0.12 log units) below it; the measured number falls inside the stated range.
By their numbers in this assay, from the lowest: compounds 3, 1, 4 and 2 (each within the scatter of the next, the first and the last beyond it).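

In this assay, among these compounds, the earlier steps all concerned the ring carrying the fluorophenyl group, whereas this one reaches the ring carrying the methoxy groups. Placing a further methoxy group on this aromatic carbon, ortho to a methoxy group and meta to a large group, gives a 1.3-fold higher number from compound 1 to compound 4 (0.12 log units; within the scatter) and so produces no difference that can be told from the scatter. Nothing at hand offers any explanation of this result.

Still open, as far as these compounds go, is whether this carbon would accept other groups equally well, such as a hydroxy group, an ethoxy group, a longer chain or an amine. From the compounds shown here alone, it is also open whether the same methoxy change would read alike on compound 2 or compound 3, where the group on the other ring differs.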